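From Furan-2-yl to Pyridin-2-yl on Compound 2

The source may hold more compounds than are shown below. What is called first, only, known or untested is meant among the compounds shown, and "the series" means these compounds.

Compound 1, `Oc1cccc(-c2cc(-c3ccco3)cc(-c3ccccc3O)n2)c1`: 1790 nM
Compound 2, `Oc1ccc(-c2cc(-c3ccco3)cc(-c3ccccc3O)n2)cc1`: > 50000 nM (a limit)
Compound 3, `Oc1ccc(-c2cc(-c3ccco3)cc(-c3ccc(O)cc3)n2)cc1`: > 50000 nM (a limit)

In a functional assay on DU-145 cells (Homo sapiens) for cytotoxicity, read by CCK-8 assay (a higher number here means a weaker inhibitor, a lower number a stronger inhibitor), compound 2 gives no number, only a limit. Compound 2 stands at the limit of > 50000 nM in this assay, at which 2 of the 3 values shown sit. Compound 4, `Oc1ccc(-c2cc(-c3ccccn3)cc(-c3ccccc3O)n2)cc1`, differs from compound 2 by pyridin-2-yl in place of furan-2-yl on an aromatic carbon. The two measured steps concern hydroxyphenyl groups only: an at least 27-fold higher number from compound 1 to compound 2 (1.44 log units; beyond the scatter) was large, while a step that the two limits leave unreadable from compound 2 to compound 3 cannot be read between its two limits. Within the data shown here, neither touches the five-membered ring, so no measured step bears on the change to compound 4. Starting from a limit, compound 4 is expected to give 40000 nM, between 8000 nM and 200000 nM, most likely again reported as a limit. This estimate means an at least 1.2-fold lower number from compound 2 to compound 4 (0.09 log units; that floor lies within the scatter).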

Compound 4, half-maximal inhibitory concentration: 25400 nM
Compound 4: the middle estimate sits 1.6-fold (0.20 log units) above what was measured; measured number inside the range.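

Compound 2 is held only by a limit in this assay: the limit of > 50000 nM in this assay, at which 2 of the 4 values shown sit. With pyridin-2-yl opposite the ring nitrogen, compound 4 gives a real number of 25400 nM and so, unlike compound 2, falls inside the measurable range. On these data alone, the change reads as an at least 1.9-fold lower number from compound 2 to compound 4 (0.29 log units; that floor lies within the scatter), so only a floor is known and the true size stays unknown.

As far as these compounds go, whether an amine or a carboxylic acid at this position would move the number further remains open. So does whether pyridin-2-yl would act the same way alongside the 3-hydroxyphenyl group of compound 1.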